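A few compounds are considered here, and "the series" means these few. Any claim that something is new, unique, unknown or untested is made for them only; others in the source may bear on it.

Going by the values given here, compound 2 `Cc1ccc(NC(=O)Nc2c(C(C)C)cccc2C(C)C)cc1` gives 250 nM in an assay on isolated protein for inhibition of acyl-CoA:cholesterol acyltransferase (Oryctolagus cuniculus) (a lower number here means a stronger inhibitor, a higher number a weaker inhibitor), the highest of the two numbers so far; compound 1 `CCCCCCCCCCc1ccc(NC(=O)Nc2c(C(C)C)cccc2C(C)C)cc1` gives 13 nM in this assay. Among the compounds with values here, the one step in hand, a 19-fold higher number from compound 1 to compound 2 (1.28 log units; beyond the scatter), bears directly on the present change. Compound 3 `CCCCCCc1ccc(NC(=O)Nc2c(C(C)C)cccc2C(C)C)cc1` differs from compound 2 by pentyl in place of hydrogen on a saturated chain carbon bound to an aromatic carbon. Pentyl is a shorter chain than the nonyl lost in that step, so a lower number is expected, of a size somewhat under that step. The expected step is a 6.3-fold lower number from compound 2 to compound 3 (0.80 log units; beyond the scatter) in this assay. Compound 3 is estimated at 40 nM, within 15 nM to 120 nM.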

Compound 3, half-maximal inhibitory concentration: 26 nM
For compound 3 the middle estimate is 1.5-fold (0.19 log units) above the measured one, and the stated range covers the measured number.
By their numbers in this assay, from the lowest: compounds 1 and 3 (each within the scatter of the next); then compound 2.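

In this assay, pentyl in place of hydrogen on a saturated chain carbon bound to an aromatic carbon already gives most of what the chain offers, with a 9.6-fold lower number from compound 2 to compound 3 (0.98 log units; beyond the scatter) as a step beyond the scatter. The butyl further out adds nothing that can be read, since a 2.0-fold higher number from compound 1 to compound 3 (0.30 log units; within the scatter) leaves compound 1 and compound 3 within the scatter of each other. Between these three compounds, the requirement at this position is thus met by a chain of moderate length. Open, going by these compounds, is how an ethyl chain, a branched chain, or a chain ending in an amine or a carboxylic acid would behave. Nothing at hand explains the effect of the chain.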